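Saturated six-membered replacements for the aryl group on the core

The compounds below may be only part of what the source reports. "The series", "measured", "known", "first", "only" and "open" are said of these compounds alone.

Measured compounds: compound 1 `C[C@@H](O[C@H]1CN2C(=O)C=C(c3ccccc3)CC2[C@@H]1c1ccc(F)cc1)c1cc(C(F)(F)F)cc(C(F)(F)F)c1` gives 0.93 nM in an assay on CHO cells for displacement of a labelled ligand from Substance-P receptor (Homo sapiens); a higher number here means a weaker inhibitor, a lower number a stronger inhibitor; compound 2 `C[C@@H](O[C@H]1CN2C(=O)C=C(C3=CCC(O)CC3)CC2[C@@H]1c1ccc(F)cc1)c1cc(C(F)(F)F)cc(C(F)(F)F)c1` gives 0.18 nM.

Compound 1 stands at the higher of the two numbers; compound 2 sits a 5.2-fold lower number from compound 1 to compound 2 (0.71 log units; beyond the scatter). Compound 3 `C[C@@H](O[C@H]1CN2C(=O)C=C(C3CCOCC3)CC2[C@@H]1c1ccc(F)cc1)c1cc(C(F)(F)F)cc(C(F)(F)F)c1` differs from compound 1 by oxan-4-yl in place of phenyl on a double-bonded ring carbon. For the measured compounds named here, the only step that bears on it is the one from compound 1 to compound 2, where a non-aromatic six-membered ring bearing an oxygen replaced the phenyl and lowered the number beyond the scatter. A lowering in the same direction, though less certain, is therefore expected for compound 3, estimated as a 1.9-fold lower number from compound 1 to compound 3 (0.27 log units; within the scatter). Compound 3 is expected at 0.5 nM, within 0.15 nM to 1.6 nM.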

Compound 3, half-maximal inhibitory concentration: 0.09 nM
Compound 3: middle estimate off by 5.6-fold (0.74 log units), on the high side; measured number below the stated range.
By their numbers in this assay, from the lowest: compounds 3 and 2 (each within the scatter of the next); then compound 1.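

For the compounds shown here, a non-aromatic ring without a double bond on it is accepted on this double-bonded ring carbon of the shared core: oxan-4-yl in place of phenyl gives a 10-fold lower number from compound 1 to compound 3 (1.01 log units; beyond the scatter), the largest step so far. The hydroxyl and ring double bond of compound 2 are not required to reach this level, since a 2.0-fold lower number from compound 2 to compound 3 (0.30 log units; within the scatter) leaves the two groups indistinguishable. Nothing in hand accounts for either step.

Open, from the compounds shown here alone, is whether the ring oxygen of oxan-4-yl matters, which a comparison with cyclohexyl would test. Also open, going by these compounds, is whether a ring amine such as piperidin-4-yl holds the same level.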